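Swapping the Halogenated Phenyl on the Triazole Nitrogen

The source may hold more compounds than are shown below. What is called first, only, known or untested is meant among the compounds shown, and "the series" means these compounds.

Compound 2 `O=C(Nc1cccc(OCc2cn(-c3ccc(Cl)cc3)nn2)c1)Nc1ccc(Cl)c(C(F)(F)F)c1` was tested in a functional assay on HepG2 cells (Homo sapiens) for inhibition, read by MTT assay, with a stated time of 72 h (on this read-out higher numbers stand for weaker inhibition and lower numbers for stronger inhibition), and gives 2490 nM. Its only companion, compound 1 `O=C(Nc1cccc(OCc2cn(-c3ccc(F)cc3)nn2)c1)Nc1ccc(Cl)c(C(F)(F)F)c1`, gives 1350 nM in this assay, and the two numbers lie within the usual scatter of each other, as the step of a 1.8-fold higher number from compound 1 to compound 2 (0.27 log units; within the scatter) shows. Compound 3 `O=C(Nc1cccc(OCc2cn(-c3ccccc3Br)nn2)c1)Nc1ccc(Cl)c(C(F)(F)F)c1` differs from compound 2 in one place: 2-bromophenyl in place of 4-chlorophenyl on an aromatic nitrogen. Going by the values given here, the one step that bears on this, a change of halogen on that phenyl, a 1.8-fold higher number from compound 1 to compound 2 (0.27 log units; within the scatter), stayed within the scatter, so the expectation is no shift beyond the scatter, a 1.0-fold lower number from compound 2 to compound 3 (0.02 log units; within the scatter). Compound 3 is therefore expected to give 2400 nM, ranging from 900 nM to 6500 nM.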

Compound 3, half-maximal inhibitory concentration: 2810 nM
The estimate for compound 3 lay 1.2-fold (0.07 log units) below the measured number, and the stated range covers the measured number.
By their numbers in this assay, from the lowest: compounds 1, 2 and 3 (each within the scatter of the next, the first and the last beyond it).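

The change from 4-chlorophenyl to 2-bromophenyl gives a 1.1-fold higher number from compound 2 to compound 3 (0.05 log units; within the scatter) in this assay, so a bromine in the 2-bromophenyl arrangement reads much like a chlorine in the 4-chlorophenyl one. Going by these compounds alone, replacing 4-fluorophenyl with the same group gives a 2.1-fold higher number from compound 1 to compound 3 (0.32 log units; beyond the scatter), the first step on this aromatic nitrogen to pass the scatter, though only modestly. Nothing available gives a cause for either step.

From the compounds shown here alone, in these compounds, the halogen and its place on the ring change together, so their separate contributions stay open. Going by these compounds, how an unsubstituted phenyl or a methoxy-bearing phenyl would read here also remains open.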